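A few compounds are considered here, and "the series" means these few. Any claim that something is new, unique, unknown or untested is made for them only; others in the source may bear on it.

Measured so far in an ADME assay on the whole organism with Oryza sativa as the target, tested at 10 uM; on this read-out higher numbers stand for a weaker effect at the one concentration tested and lower numbers for a stronger effect:
- compound 1, `CC(C)c1ccc(NC(=O)N[C@H](C)c2ccccc2)cc1`, 49%
- compound 2, `CCCCc1ccc(NC(=O)N[C@H](C)c2ccccc2)cc1`, 28%

Among the measured compounds shown here, compound 2 stands lowest of the two numbers on this read-out; its nearest neighbour is compound 1, and the one measured step runs a number 21 percentage points lower from compound 1 to compound 2 (beyond the scatter).

Compound 3, `CCCCCc1ccc(NC(=O)N[C@H](C)c2ccccc2)cc1`, is not yet measured. It differs from compound 2 by methyl in place of hydrogen on a saturated chain carbon, four bonds along the chain from an aromatic carbon.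

For the measured compounds named here, only the step from compound 1 to compound 2 bears on this change, and it is a loose guide: that step exchanged a branched group for a longer straight chain, while the present step adds one carbon to the chain as it stands. On that single step, a further move downward in this assay of roughly half its size is the expectation, though a step within the scatter would not surprise. For compound 3 the expected step is a number 9 percentage points lower from compound 2 to compound 3 (within the scatter). Compound 3 is therefore estimated at 19%, in the range 7% to 34%.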

Compound 3, a percentage reported as activity, at one concentration (the size of the read-out at that concentration, not a potency): 97%
For compound 3 the middle estimate is 78 percentage points below the measured one; the whole stated range lies below it.
By their numbers in this assay, from the lowest: compound 2; then compound 1; then compound 3.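

In this assay, the chain does not respond smoothly: methyl in place of hydrogen on a saturated chain carbon, four bonds along the chain from an aromatic carbon, gives a number 69 percentage points higher from compound 2 to compound 3 (beyond the scatter) and reverses the direction of a number 21 percentage points lower from compound 1 to compound 2 (beyond the scatter) in a single added carbon. The direct comparison gives a number 48 percentage points higher from compound 1 to compound 3 (beyond the scatter) as well, so across these three compounds the read-out does not follow chain length in one direction, and compound 3 goes against any such trend. No measurement at hand accounts for this reversal.

A longer chain such as hexyl could stay at the high end of this read-out or come back down, and propyl would show how the straight chains behave below butyl. A hydroxyl group or an ether oxygen within the pentyl chain would test whether the reversal depends on an all-carbon chain.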